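Piperazine nitrogen substituent and microsomal stability: compound 4

This account rests on a few compounds, and the source may have more. Where it says the series, first, only, none or still open, it means among the compounds named here.

Among the measured compounds shown here, compound 3 `CC(C)N1CCN(c2cccc3c2C[C@H](CN(C)[C@H]2CCCc4cccnc42)NC3)CC1` stands at the bottom of the three numbers so far. In an ADME assay on microsomes from liver (Mus musculus) for metabolic stability, read by LC-MS, with a stated time of 10 min (on this read-out higher numbers stand for a more stable compound and lower numbers for a less stable compound), compound 3 gives 15.1%, whereas compound 2 `C[C@@H]1CN(c2cccc3c2C[C@H](CN(C)[C@H]2CCCc4cccnc42)NC3)C[C@H](C)N1` gives 85.6% and compound 1 `CCCN(C[C@H]1Cc2c(cccc2N2CCNCC2)CN1)[C@H]1CCCc2cccnc21` gives 87.4%; both gaps are beyond the scatter. Compound 4 `CN1CCN(c2cccc3c2C[C@H](CN(C)[C@H]2CCCc4cccnc42)NC3)CC1` differs from compound 3 in one place: methyl in place of isopropyl on an amine nitrogen in a ring, which cut one bond further out reads 4-isopropylpiperazin-1-yl to 4-methylpiperazin-1-yl.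

For the measured compounds named here, only one measured step touches this part of the molecule: a number 70.5 percentage points lower from compound 2 to compound 3 (beyond the scatter), where 4-isopropylpiperazin-1-yl replaced 3,5-dimethylpiperazin-1-yl. Going by the values given here, that step altered the group on the ring nitrogen and the groups on the ring carbons at once, so it cannot be split, and no measured compound carries a methyl on the ring nitrogen. The two compounds without a group on that nitrogen, compound 1 and compound 2, sit high; compound 3 with the isopropyl sits far below. Methyl is smaller than isopropyl yet still a group on that nitrogen. The step to compound 4 is therefore expected to run upward, with the estimated step being a number 29.9 percentage points higher from compound 3 to compound 4 (beyond the scatter), though with wide uncertainty. The estimate for compound 4 in this assay is 45%, within 20% to 75%.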

Compound 4, percent of the compound remaining: 17%
Estimate against measurement, compound 4: 28 percentage points above; the whole stated range lies above it.
By their numbers in this assay, from the lowest: compounds 3 and 4 (each within the scatter of the next); then compounds 2 and 1 (each within the scatter of the next).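

In this assay, methyl in place of isopropyl on the amine nitrogen in the ring gives a number 1.9 percentage points higher from compound 3 to compound 4 (within the scatter), so these two groups cannot be told apart on this read-out, and the low number of compound 3 is not peculiar to isopropyl. The step of a number 68.6 percentage points lower from compound 2 to compound 4 (beyond the scatter) lies beyond the scatter, as does a number 70.5 percentage points lower from compound 2 to compound 3 (beyond the scatter), so both 4-methylpiperazin-1-yl and 4-isopropylpiperazin-1-yl stand far from 3,5-dimethylpiperazin-1-yl, although each of these steps alters the ring nitrogen and the ring carbons at once and neither can be split. No measurement offered here accounts for the low numbers of compound 3 and compound 4.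

Still open, on these data alone, is whether the gap follows the group on the ring nitrogen or the two methyl groups on the ring carbons, a question that a 3,5-dimethylpiperazin-1-yl also bearing methyl on its ring nitrogen would bear on directly. Also open, as far as these compounds go, is how a group of another kind on that nitrogen, such as acetyl or 2-hydroxyethyl, would read in this assay.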